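Swapping the Chlorophenyl Arm: What Clearance Might Follow

The source may hold more compounds than are shown below. What is called first, only, known or untested is meant among the compounds shown, and "the series" means these compounds.

Compound 2 `O=S(=O)(c1cc(Cl)cc(Cl)c1)c1cnc2cc(F)ccc2c1-c1ccc(Cl)cc1` has the lowest number of the three measured compounds in an ADME assay on microsomes from liver (Homo sapiens) for metabolic stability, tested at 2.5 uM (a higher number here means faster removal of the compound, a lower number slower removal), where compound 2 gives 0.13 mL/min. Compound 1 `O=S(=O)(c1ccc(F)c(Cl)c1)c1cnc2cc(F)ccc2c1-c1ccc(Cl)cc1` gives 0.39 mL/min, and compound 3 `COc1ccc(S(=O)(=O)c2cnc3cc(F)ccc3c2-c2ccc(Cl)cc2)cc1` gives 1.28 mL/min; the steps of a 3.0-fold lower number from compound 1 to compound 2 (0.48 log units; beyond the scatter) and a 9.8-fold higher number from compound 2 to compound 3 (0.99 log units; beyond the scatter) both change the group on the sulfonyl sulfur. Compound 4 `COc1cccc(-c2c(S(=O)(=O)c3cc(Cl)cc(Cl)c3)cnc3cc(F)ccc23)c1` differs from compound 2 at a different place: 3-methoxyphenyl in place of 4-chlorophenyl on an aromatic carbon. Among the compounds with values here, no measured step changes this group, so the measured steps show only how far clearance has moved. Within the data shown here, a modest rise is expected for compound 4 because the one step that introduced a methoxyphenyl group, a 9.8-fold higher number from compound 2 to compound 3 (0.99 log units; beyond the scatter), went upward, giving an expected step of a 2.7-fold higher number from compound 2 to compound 4 (0.43 log units; beyond the scatter). Compound 4 is therefore estimated at 0.35 mL/min, within 0.12 mL/min to 1 mL/min.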

Compound 4, intrinsic clearance in a liver preparation (reported as CLH), per the amount of preparation that the assay uses: 1.51 mL/min
The estimate for compound 4 lay 4.3-fold (0.63 log units) below the measured number; the measured number lies above the stated range.
By their numbers in this assay, from the lowest: compound 2; then compound 1; then compounds 3 and 4 (each within the scatter of the next).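

The group on the aromatic carbon opposite the ring nitrogen also matters in this assay, not only the group on the sulfonyl sulfur: 3-methoxyphenyl in place of 4-chlorophenyl gives a 12-fold higher number from compound 2 to compound 4 (1.07 log units; beyond the scatter). This single swap removes the chlorine, adds the methoxy group and moves the substituent on the ring, so the step cannot say which of these changes counts. No measurement here explains the rise.

From the compounds shown here alone, it remains open how a plain phenyl or a 3-chlorophenyl at this position would compare, which would help separate those changes. Going by these compounds, whether the same swap gives a similar step with another group on the sulfonyl sulfur also remains open.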